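A Single Methyl Added on Two Related Scaffolds

The source may hold more compounds than are shown below. What is called first, only, known or untested is meant among the compounds shown, and "the series" means these compounds.

Compound 1 `O=C1c2ccccc2C(=O)N1c1ccc(-c2ccccc2)cc1` is the starting point. In a functional assay on HL-60 cells (Homo sapiens) for cytotoxicity, read by MTT assay, with a stated time of 24 h (on this read-out lower numbers stand for stronger inhibition and higher numbers for weaker inhibition), compound 1 gives 119000 nM. Compound 2 `Cc1ccc2c(c1)C(=O)N(c1ccc(-c3ccccc3)cc1)C2=O` carries a methyl in place of hydrogen on an aromatic carbon, the change marked as methyl in place of hydrogen on an aromatic carbon, and in this assay compound 2 gives 59500 nM. That step is a 2.0-fold lower number from compound 1 to compound 2 (0.30 log units; within the scatter).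

Compound 3 `Nc1ccc(CN2C(=O)c3ccccc3C2=O)cc1` has a different core. In this assay compound 3 reaches only a limit of the assay, > 200000 nM. This is the case described by the limit of > 200000 nM in this assay, at which 1 of the 3 values shown sits. How the core of compound 3 differs from the core of compound 1 is not broken down here.

Compound 4 `Cc1cccc2c1C(=O)N(Cc1ccc(N)cc1)C2=O` is not yet measured. It differs from compound 3 by methyl in place of hydrogen on an aromatic carbon. For the measured compounds named here, this is the same kind of change as the one from compound 1 to compound 2, but the methyl now sits ortho to a fused ring and meta to a fused ring, rather than meta to a fused ring and para to a fused ring.

In this assay the expected step is a step that the limit leaves unreadable from compound 3 to compound 4, which rests on compound 1 and compound 2 showing a 2.0-fold lower number from compound 1 to compound 2 (0.30 log units; within the scatter) and on compound 3 giving only > 200000 nM. For compound 4 the estimate is 300000 nM, most likely again reported only as a limit.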

Compound 4, half-maximal inhibitory concentration: > 200000 nM
Compound 4 was reported as a limit (the forecaster's own chance of this, stated with the estimate: 80%); the middle value does not contradict the limit.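

In this assay, compound 3 and compound 4 are both reported only as a limit, so the size of the step between them cannot be read: the limit of > 200000 nM in this assay, at which 2 of the 4 values shown sit.

The compounds shown leave open whether methyl in place of hydrogen on an aromatic carbon changes the read-out at all on the core of compound 3.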